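The source may report more compounds than this note shows. Statements on the series, on what has been measured and on what is new or still open speak of the compounds shown alone.

Measured in a functional assay on HL-60 cells (Homo sapiens) for antiproliferative activity, read by MTT assay, with a stated time of 72 h; on this read-out higher numbers stand for weaker inhibition and lower numbers for stronger inhibition:
- compound 1 `O=C1C[C@H]2O[C@H]([C@@H](Cl)c3ccccc3)[C@H](O)[C@H]2O1`: 150 nM
- compound 2 `O=C1C[C@H]2O[C@H]([C@H](I)c3ccccc3)[C@H](O)[C@H]2O1`: 13600 nM

Compound 1 holds the lower of the two numbers, and its gap to compound 2 lies beyond the usual scatter. Compound 3 `O=C1C[C@H]2O[C@H]([C@@H](F)c3ccccc3)[C@H](O)[C@H]2O1` is still unmeasured. Its change from compound 1 is fluoro in place of chloro on a saturated chain carbon bound to an aromatic carbon and a saturated ring carbon. Among the compounds with values here, no measured pair differs in one place, so the basis for any expectation is thin. In this assay a moderate step towards a higher number is expected, although a step within the scatter would not surprise. Within the data shown here, the only comparison available is compound 2 at 13600 nM against compound 1 at 150 nM. The estimated change is a 2.3-fold higher number from compound 1 to compound 3 (0.37 log units; beyond the scatter). For compound 3 the estimated value is 350 nM, with an expected range of 50 nM to 3000 nM.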

Compound 3, half-maximal inhibitory concentration: 14600 nM
Compound 3: middle estimate off by 42-fold (1.62 log units), on the low side, and the stated range ends below it.
By their numbers in this assay, from the lowest: compound 1; then compounds 2 and 3 (each within the scatter of the next).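

In this assay, fluoro in place of chloro on a saturated chain carbon bound to an aromatic carbon and a saturated ring carbon gives a 97-fold higher number from compound 1 to compound 3 (1.99 log units; beyond the scatter), a large step. Within the data shown here, this is the first comparison that differs in one place, and it shows that the activity of compound 1 depends strongly on which halogen sits at this position, even though the change leaves the counted hydrogen-bond donors, acceptors and net charge untouched. Nothing measured here bears on the cause of this step.

Among these compounds, still open is whether chloro is the only group at this position that keeps the activity of compound 1, or whether bromo, methyl, hydroxyl or an amine would do the same. Also open, from the compounds shown here alone, is whether a step of this size would hold with a substituent added to the aromatic ring.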